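Thienopyrimidine ethers on A549 cells: a ring swap

The source may report more compounds than this note shows. Statements on the series, on what has been measured and on what is new or still open speak of the compounds shown alone.

Of the compounds shown here, three have been measured in a functional assay on A549 cells (Homo sapiens) for inhibition, read by MTT assay, with a stated time of 72 h (a lower number here means a stronger inhibitor, a higher number a weaker inhibitor), so far. Compound 1 `c1cc(N2CCCCC2)nc(Nc2ccc(Oc3ncnc4sccc34)cc2)n1` gives 4020 nM. Compound 2 `COc1ccc(C[C@H]2C(=O)N[C@@H](C)C(=O)N(C)[C@H]3Cc4cccc(c4)Oc4cc(ccc4O[C@H]4O[C@H](CO)[C@@H](O)[C@H](O)[C@H]4O)C[C@H](C(=O)N[C@H](C)C(=O)N[C@@H](C)C(=O)N2C)N(C)C3=O)cc1`, a macrocycle unrelated in build to the others, gives 1340 nM. Compound 3 `CN(c1ccc(Oc2ncnc3ccsc23)cc1)c1nccc(N2CCCC2)n1` gives 6510 nM, the highest of the three numbers; the gap to compound 1 lies within the usual scatter, while the gap to compound 2 lies beyond it, so only against compound 2 can compound 3 be called the weaker inhibitor.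

Compound 4 `CN(c1ccc(Oc2ncnc3ccsc23)cc1)c1nccc(N2CCc3ccccc3C2)n1` has not been measured. It differs from compound 3 in one place: 1,2,3,4-tetrahydroisoquinolin-2-yl in place of pyrrolidin-1-yl on an aromatic carbon. Going by the values given here, no pair of measured compounds shows what this kind of swap does in this assay, so the size and direction of the step are open. Among the compounds with values here, the only guide is that the measured compounds with the shared core sit close together in this assay, and a larger group on the same aromatic carbon is expected to keep the number in that region. The step from compound 3 to compound 4 is therefore expected to be a 1.3-fold lower number from compound 3 to compound 4 (0.11 log units; within the scatter), with no confident call on direction. Compound 4 is estimated at 5000 nM, with a range of 1500 nM to 16000 nM.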

Compound 4, half-maximal inhibitory concentration: 16200 nM
Compound 4: the middle estimate sits 3.2-fold (0.51 log units) below what was measured; measured number above the stated range.
By their numbers in this assay, from the lowest: compound 2; then compounds 1 and 3 (each within the scatter of the next); then compound 4.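

In this assay, this position now has its first readable change: 1,2,3,4-tetrahydroisoquinolin-2-yl in place of pyrrolidin-1-yl on the aromatic carbon of the six-membered aromatic ring with 2 nitrogen gives a 2.5-fold higher number from compound 3 to compound 4 (0.40 log units; beyond the scatter). The position therefore does respond to the group it carries, and this change goes toward weaker inhibition, even though the two groups match in hydrogen-bond donors, hydrogen-bond acceptors and net charge, and differ in the larger heavy-atom count and the added six-membered aromatic ring of carbon only. Nothing at hand bears on the cause of this step.

One pair cannot separate the effect of the added aromatic ring from that of the change from a five-membered to a six-membered non-aromatic ring, so a piperidin-1-yl group at this carbon on the same core would be the informative next point, and a morpholin-4-yl group or a simple dimethylamino group would extend the comparison to other amines. On these data alone, it also remains open whether the same swap gives a step of similar direction and size on the core of compound 1, which carries a piperidin-1-yl group on its own ring.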